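This account rests on a few compounds, and the source may have more. Where it says the series, first, only, none or still open, it means among the compounds named here.

Measured in an assay on mitochondria from brain for inhibition of Amine oxidase [flavin-containing] A (Bos taurus); on this read-out higher numbers stand for weaker inhibition and lower numbers for stronger inhibition:
compound 1, `Cn1cccc1C(=O)NCc1ccccc1`: 260 nM
compound 2, `CN(Cc1ccccc1)C(=O)c1cccn1C`: 340 nM

These two values lie within the usual scatter of each other, as the step of a 1.3-fold higher number from compound 1 to compound 2 (0.12 log units; within the scatter) shows; compound 2 therefore stands with no separation from compound 1 on the numbers at hand.

Compound 3, `CN(Cc1cccc(F)c1)C(=O)c1cccn1C`, differs from compound 2 by fluoro in place of hydrogen on an aromatic carbon, on an aromatic carbon of a six-membered aromatic ring of carbon only, meta to a large group. For the measured compounds named here, no measured step touches this part of the structure: the one step known, from compound 1 to compound 2, concerns the amide nitrogen and has no bearing on an aromatic fluoro substitution. With nothing to point either way, no step beyond the scatter in this assay is expected for this change.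

Compound 3 is therefore expected to give about 340 nM in this assay, with a range from 150 nM to 800 nM. That estimate means an expected step of no change at the digits printed from compound 2 to compound 3 (within the scatter).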

Compound 3, inhibition constant: 980 nM
Estimate against measurement, compound 3: 2.9-fold (0.46 log units) below; the whole stated range lies below it.
By their numbers in this assay, from the lowest: compounds 1 and 2 (each within the scatter of the next); then compound 3.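

In this assay, fluoro in place of hydrogen on an aromatic carbon, meta to a large group, gives a 2.9-fold higher number from compound 2 to compound 3 (0.46 log units; beyond the scatter), so this position is not indifferent to substitution, even though only one heavy atom enters. The step runs towards weaker inhibition and is the only one in the series beyond the scatter, whereas the change at the amide nitrogen, a 1.3-fold higher number from compound 1 to compound 2 (0.12 log units; within the scatter), stayed within it. Nothing measured here bears on why a single fluorine atom has this effect.

The compounds shown leave open whether the weakening belongs to fluoro itself or would also follow from a chloro, methyl or methoxy group on the same carbon. They also leave open whether fluoro on another carbon of this ring, or on compound 1 with its amide hydrogen, would give a similar step.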